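A few compounds are considered here, and "the series" means these few. Any claim that something is new, unique, unknown or untested is made for them only; others in the source may bear on it.

Measured so far in an ADME assay on the whole organism (strain Balb) for metabolic stability, with Mus musculus as the target, read by LC-MS, at a dose of 10 mg/kg by the oral route; a higher number here means that the compound lasts longer, a lower number that the compound disappears faster:
Compound 1 `CCc1ccc(Cl)cc1-n1cc(-c2ncnn3cccc23)cc1C(N)=O` gives 3.7 h
Compound 2 `CCc1ccc(Cl)cc1-n1cc(-c2cc(N)ncn2)cc1C(N)=O` gives 2.6 h

Compound 2, at 2.6 h, lies within the usual scatter of compound 1, so the two numbers do not separate these compounds. Compound 3 `CCc1ccc(Cl)cc1-n1cc(-c2cc(NC)ncn2)cc1C(N)=O` differs from compound 2 in one place: methyl in place of hydrogen on a nitrogen on an aromatic ring, with methyl in place of hydrogen on a nitrogen on an aromatic ring, amino becoming methylamino. For the measured compounds named here, the series holds no measured step between compounds that differ in one place, so this change has no precedent here. With so little to go on, the starting point is compound 2 at 2.6 h, and no shift beyond the scatter is expected in this assay. The expected step is a 1.1-fold lower number from compound 2 to compound 3 (0.03 log units; within the scatter). Compound 3 is estimated at 2.4 h, with a range from 1.2 h to 4.8 h.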

Compound 3, half-life: 2.4 h
The estimate for compound 3 equals the measured number at the digits printed, within the range that was stated.
By their numbers in this assay, from the lowest: compounds 3, 2 and 1 (each within the scatter of the next).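

Methyl in place of hydrogen on a nitrogen on an aromatic ring gives the series its first step between compounds that differ in one place: in this assay, amino to methylamino reads as a 1.1-fold lower number from compound 2 to compound 3 (0.03 log units; within the scatter). This nitrogen therefore takes one methyl without the half-life separating from that of the amino compound, so at this position the change does not distinguish the two groups. Nothing available bears on the reason for this result.

A single methyl shows only a small part of what this nitrogen may tolerate. Open, from the compounds shown here alone, is whether a longer chain such as ethyl or propyl, a dimethylamino group or a ring amine such as morpholine at the same place would also stay within the scatter of the amino compound or would move the half-life beyond it.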